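A few compounds are considered here, and "the series" means these few. Any claim that something is new, unique, unknown or untested is made for them only; others in the source may bear on it.

Measured in a functional assay on the whole organism (strain Kunming) with Mus musculus as the target, in the formalin test, with a stated time of 0.5 h; a higher number here means that more compound is needed for the effect, a lower number that less compound is needed:
- compound 1 `COc1cc(OC)c(OC)cc1/C=C/COC(=O)/C=C/c1cc(OC)c(OC)c(OC)c1OC`: 89 umol/kg
- compound 2 `COc1cc(OC)c(OC)cc1/C=C/COC(=O)/C=C/c1ccc(Br)cc1`: 243 umol/kg
- compound 3 `COc1cc(OC)c(OC)cc1/C=C/COC(=O)/C=C/c1ccc(OC)c(OC)c1OC`: 176 umol/kg

In this assay, compound 2 at 243 umol/kg lies within the scatter of compound 3 at 176 umol/kg. Its number is higher than that of compound 1 at 89 umol/kg, a gap beyond the scatter.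

The next compound is compound 4 `COc1cc(OC)c(OC)cc1/C=C/COC(=O)/C=C/c1ccccc1Cl`, which has 2-chlorophenyl in place of 4-bromophenyl on a double-bonded chain carbon bound to a double-bonded chain carbon.

For the measured compounds named here, only one measured step links two compounds directly, a 2.0-fold higher number from compound 1 to compound 3 (0.30 log units; within the scatter), and it stays within the scatter. That step is hydrogen in place of methoxy on an aromatic carbon, so it bears on this change only loosely. Going by the values given here, no measured step replaces either group involved here, and so the data give no direction. No step beyond the scatter is expected in this assay.

The expected step is a 1.3-fold lower number from compound 2 to compound 4 (0.11 log units; within the scatter).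

For compound 4 the estimated value is 190 umol/kg, with an expected range from 85 umol/kg to 420 umol/kg.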

Compound 4, dose for half-maximal effect: 260 umol/kg
The estimate for compound 4 lay 1.4-fold (0.14 log units) below the measured number, and the stated range covers the measured number.
By their numbers in this assay, from the lowest: compounds 1, 3, 2 and 4 (each within the scatter of the next, the first and the last beyond it).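

In this assay, putting 2-chlorophenyl in place of 4-bromophenyl on a double-bonded chain carbon bound to a double-bonded chain carbon gives a 1.1-fold higher number from compound 2 to compound 4 (0.03 log units; within the scatter). For the compounds shown here, this is the first measured step at this place, and it shows that 4-bromophenyl and 2-chlorophenyl cannot be told apart in this test, although the halogen and its place on the ring differ between them. Nothing measured here accounts for this result.

The halogen and its place on the ring change together in this single step, so the compounds shown leave the contribution of each unresolved. They also leave open whether the same place accepts a phenyl ring carrying a group of another kind, such as an amine or a carboxylic acid.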